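A few compounds are considered here, and "the series" means these few. Any claim that something is new, unique, unknown or untested is made for them only; others in the source may bear on it.

Measured compounds:
Compound 1 `CN(C)c1cc2[nH]c(C3CCCCC3)nc2cc1NC(=O)c1ccc(OC(F)F)cc1`: in an ADME assay on Vero cells (Chlorocebus sabaeus) for cytotoxicity, read by resazurin assay, with a stated time of 3 days (on this read-out lower numbers stand for stronger inhibition and higher numbers for weaker inhibition), compound 1 gives > 100 ug/mL, which is a limit of the assay rather than a number.
Compound 2 `CCCCCC(=O)Nc1cc2nc(C3CCCCC3)[nH]c2cc1N(C)C`: in this assay compound 2 gives > 100 ug/mL, again a limit of the assay.

Going by the values given here, compound 2 therefore stands at the top of what the assay reports, and it shares that position with the only other compound measured, as the limit of > 100 ug/mL in this assay, at which 2 of the 2 values shown sit, shows. Among the compounds with values here, the one step that connects the two measured compounds, a step that the two limits leave unreadable from compound 1 to compound 2, cannot be sized, since both of its ends are limits.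

Compound 3 `CN(C)c1cc2[nH]c(C3CCCCC3)nc2cc1NC(=O)c1cccs1` differs from compound 2 by thiophen-2-yl in place of pentyl on a carbonyl carbon. Within the data shown here, no measured step bears on this change in a readable way; the only footing is that both compounds shown sit at the limit (the limit of > 100 ug/mL in this assay, at which 2 of the 2 values shown sit). The step of a number no higher from compound 2 to compound 3 (the limit leaves the size open) is accordingly expected to be none beyond the scatter, and compound 3 is most likely to be reported as a limit as well. Compound 3 is estimated at 100 ug/mL, with a range from 60 ug/mL to 200 ug/mL.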

Compound 3, half-maximal inhibitory concentration: > 100 ug/mL
Compound 3 gave a limit, no number; the forecaster's own chance of this, stated with the estimate: 80%; the middle value sits exactly at the limit.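

In this assay compound 3 gives > 100 ug/mL, which is a limit of the assay and not a number. Going by these compounds alone, neither the step from compound 2 to compound 3 nor the one from compound 1 to compound 3 can be read: the limit of > 100 ug/mL in this assay, at which 3 of the 3 values shown sit. The compounds shown leave open how the three actually compare in this assay, and whether the group on the carbonyl carbon changes the read-out at all.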